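Chain length and histone deacetylase 8 inhibition

The compounds below may be only part of what the source reports. "The series", "measured", "known", "first", "only" and "open" are said of these compounds alone.

Measured compounds:
compound 1, `CC[C@H]1OC(=O)[C@H](C)C(=O)[C@H](C)[C@@H](O[C@@H]2O[C@H](C)C[C@H](N(C)Cc3cccc(-c4cn(CCCCCC(=O)NO)nn4)c3)[C@H]2O)[C@@](C)(OC)C[C@@H](C)C2=NCCN3C(=O)O[C@@]1(C)[C@H]3[C@H]2C`, 3230 nM
compound 2, `CC[C@H]1OC(=O)[C@H](C)C(=O)[C@H](C)[C@@H](O[C@@H]2O[C@H](C)C[C@H](N(C)Cc3cccc(-c4cn(CCCCCCC(=O)NO)nn4)c3)[C@H]2O)[C@@](C)(OC)C[C@@H](C)C2=NCCN3C(=O)O[C@@]1(C)[C@H]3[C@H]2C`, 310 nM
compound 3, `CC[C@H]1OC(=O)[C@H](C)C(=O)[C@H](C)[C@@H](O[C@@H]2O[C@H](C)C[C@H](N(C)Cc3ccc(-c4cn(CCCC(=O)NO)nn4)cc3)[C@H]2O)[C@@](C)(OC)C[C@@H](C)C2=NCCN3C(=O)O[C@@]1(C)[C@H]3[C@H]2C`, 2240 nM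

All three were tested in an assay for inhibition of histone deacetylase 8 (Homo sapiens), read by mass spectrometry, with a stated time of 60 min; on this read-out lower numbers stand for stronger inhibition and higher numbers for weaker inhibition. Compound 1 gives 3230 nM and compound 2 gives 310 nM. The two differ in one place: (hydroxycarbamoyl)methyl in place of hydroxycarbamoyl on a saturated chain carbon, five bonds along the chain from an aromatic nitrogen. That single change produced a 10-fold lower number from compound 1 to compound 2 (1.02 log units; beyond the scatter).

Compound 3, with 2240 nM, sits close to compound 1, and the two values are within the usual scatter of each other. The difference between the core of compound 1 and the core of compound 3 is not broken down here.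

Compound 4, `CC[C@H]1OC(=O)[C@H](C)C(=O)[C@H](C)[C@@H](O[C@@H]2O[C@H](C)C[C@H](N(C)Cc3ccc(-c4cn(CCCCC(=O)NO)nn4)cc3)[C@H]2O)[C@@](C)(OC)C[C@@H](C)C2=NCCN3C(=O)O[C@@]1(C)[C@H]3[C@H]2C`, has not yet been measured in this assay. It stands to compound 3 as compound 2 stands to compound 1: (hydroxycarbamoyl)methyl in place of hydroxycarbamoyl on a saturated chain carbon, three bonds along the chain from an aromatic nitrogen. This is the same kind of change, but not the same change. In compound 1 the group sits five bonds along the chain from an aromatic nitrogen, in compound 3 three bonds along the chain from an aromatic nitrogen.

Given the one precedent, compound 4 is expected to show a 3.2-fold lower number from compound 3 to compound 4 (0.51 log units; beyond the scatter), a smaller step than the one from compound 1 to compound 2, since the shorter chain and the unbroken-down core difference leave the transfer uncertain. The expected value for compound 4 is 700 nM, with a likely range from 200 nM to 2500 nM.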

Compound 4, half-maximal inhibitory concentration: 3210 nM
The estimate for compound 4 lay 4.6-fold (0.66 log units) below the measured number; the whole stated range lies below it.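

In this assay, lengthening the chain on the core of compound 3 gave a 1.4-fold higher number from compound 3 to compound 4 (0.16 log units; within the scatter), so on this core the added carbon made no difference that stands out from the usual scatter. The same change therefore did not carry over from one core to the other with the same result, and the two steps are clearly not alike: the same change on two cores in this assay, a 10-fold lower number (1.02 log units; beyond the scatter) from compound 1 to compound 2 and a 1.4-fold higher number (0.16 log units; within the scatter) from compound 3 to compound 4, 15-fold (1.17 log units) apart, beyond the scatter of two such steps This does not show which difference matters, since the two pairs differ both in their cores and in where the change sits, at three bonds along the chain from an aromatic nitrogen in one pair and five in the other, and two pairs cannot separate these or show how the change would behave on any further core.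

Still open, as far as these compounds go, is whether a longer chain on the core of compound 3, matching the chain of compound 2, would bring a lower number in this assay, a comparison that would separate the effect of the core from that of chain length. Also open, from the compounds shown here alone, is how a carboxylic acid in place of the hydroxycarbamoyl end of the chain would read on either core.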